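The source may hold more compounds than are shown below. What is called first, only, known or untested is meant among the compounds shown, and "the series" means these compounds.

Compound 1 `O=C1NC(=S)S/C1=C\c1cc2cc(Cl)ccc2nc1Cl` — in a toxicity assay on A549 cells (Homo sapiens) for cytotoxicity, read by MTT assay, with a stated time of 48 h (a lower number here means a stronger inhibitor of growth, a higher number a weaker inhibitor of growth), compound 1 gives > 100 ug/mL, a limit of the assay rather than a number.
Compound 2 `Cc1cccc2cc(/C=C3\SC(=S)NC3=O)c(Cl)nc12` — in this assay compound 2 gives > 100 ug/mL, again a limit.
Compound 3 `COc1ccc2cc(/C=C3\SC(=S)NC3=O)c(Cl)nc2c1` — in this assay compound 3 gives > 100 ug/mL, also a limit.

These three compounds share one core and differ only in the substituent on the carbon-only ring of that core. None of them reached a number in this assay: every value is a limit, so compound 1 stands at the same point as the other two and no order among them can be read. For the measured compounds named here, the whole set sits at the limit of > 100 ug/mL in this assay, at which 3 of the 3 values shown sit, which leaves no measured step to build on.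

Compound 4 `O=C1NC(=S)S/C1=C\c1cc2cc(F)ccc2nc1Cl` is the untested member. It differs from compound 1 by fluoro in place of chloro on an aromatic carbon. Going by the values given here, with no step between measured compounds to compare, the safest expectation is that the change from chloro to fluoro leaves the result where the rest of the set lies, and the expected step from compound 1 to compound 4 in this assay is a step that the limit leaves unreadable from compound 1 to compound 4. Compound 4 is therefore estimated at 150 ug/mL, within a range from 60 ug/mL to 400 ug/mL, most likely reported again only as a limit.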

Compound 4, concentration for 50% growth inhibition: > 100 ug/mL
Compound 4 was reported as a limit (the forecaster's own chance of this, stated with the estimate: 80%); the middle value is on the limit's open side.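

For the compounds shown here, compound 1 and compound 4 are both reported only as limits in this assay, so the change from chloro to fluoro gives no step that can be read: the limit of > 100 ug/mL in this assay, at which 4 of the 4 values shown sit. The compounds shown leave open whether any substituent on this ring of the shared core would give a measurable value.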